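Replacing the Aryl Ring Substituent With a Thiadiazole

The source may hold more compounds than are shown below. What is called first, only, known or untested is meant among the compounds shown, and "the series" means these compounds.

Compound 1 `CCC(C)(C)Cc1c[nH]c(CCc2ccc(-c3cnccn3)cc2)n1` — in a functional assay on HEK293 cells for agonist activity at Bombesin receptor subtype-3 (Homo sapiens), read by luminescence and calcium flux, with a stated time of 10 min (on this read-out higher numbers stand for an effect only at larger amounts of compound and lower numbers for an effect already at smaller amounts), compound 1 gives 431 nM.
Compound 2 `CCC(C)(C)Cc1c[nH]c(CCc2ccc(-c3cccc(C#N)n3)cc2)n1` — in this assay compound 2 gives 193 nM.

Within the data shown here, compound 2 holds the lowest of these two numbers; its only neighbour is compound 1, and the step of a 2.2-fold lower number from compound 1 to compound 2 (0.35 log units; beyond the scatter) separates them. Compound 3 `CCC(C)(C)Cc1c[nH]c(CCc2ccc(-c3csnn3)cc2)n1` differs from compound 2 in one place: 1,2,3-thiadiazol-4-yl in place of 6-cyanopyridin-2-yl on an aromatic carbon. Among the measured compounds shown here, only one measured step exists, a 2.2-fold lower number from compound 1 to compound 2 (0.35 log units; beyond the scatter), and it exchanged one six-membered ring for another; the present change moves to a five-membered ring, so that step bears on it only loosely. No direction can be read from the data, and a step in this assay of roughly a 2.1-fold higher number from compound 2 to compound 3 (0.32 log units; beyond the scatter) is expected, with wide uncertainty. Compound 3 is estimated at 400 nM, within 120 nM to 1300 nM.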

Compound 3, half-maximal effective concentration: 538 nM
The estimate for compound 3 lay 1.3-fold (0.13 log units) below the measured number, and the stated range covers the measured number.
By their numbers in this assay, from the lowest: compound 2; then compounds 1 and 3 (each within the scatter of the next).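

In this assay, the first five-membered ring at this aromatic carbon gives a 2.8-fold higher number from compound 2 to compound 3 (0.45 log units; beyond the scatter), so 1,2,3-thiadiazol-4-yl does not keep the lower number seen with 6-cyanopyridin-2-yl. Against the other six-membered ring, it gives a 1.2-fold higher number from compound 1 to compound 3 (0.10 log units; within the scatter), which shows that moving to the smaller ring need not change the number. No supporting data explain the gap between these rings. Still open, as far as these compounds go, is how an amine or a carboxylic acid in place of the nitrile on the pyridine ring would read, and whether a plain phenyl ring at this position would match either group.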